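The compounds below may be only part of what the source reports. "The series", "measured", "known", "first", "only" and "open" are said of these compounds alone.

Measured so far:
compound 1, `COc1cc(-c2nnc3n2NC(c2ccco2)C(C(=O)c2ccc(Br)cc2)S3)cc(OC)c1OC`; in a functional assay on HepG2 cells (Homo sapiens) for cytotoxicity, read by MTT assay, with a stated time of 48 h (on this read-out lower numbers stand for stronger inhibition and higher numbers for weaker inhibition), compound 1 returns > 100000 nM, which is a limit of the assay and not a number.
compound 2, `COc1cc(-c2nnc3n2NC(c2ccco2)C(C(=O)c2cccs2)S3)cc(OC)c1OC`; in this assay compound 2 gives 64100 nM.

Going by the values given here, compound 2 thus holds the only number in this assay; the one further value is a limit. Among the compounds with values here, the sole measured step, an at least 1.5-fold lower number from compound 1 to compound 2 (0.19 log units; that floor lies within the scatter), lies within the scatter, and its floor follows from the limit of > 100000 nM in this assay, at which 1 of the 2 values shown sits. Compound 3, `COc1cc(-c2nnc3n2NC(c2ccco2)C(C(=O)C2CC2)S3)cc(OC)c1OC`, differs from compound 2 by cyclopropyl in place of thiophen-2-yl on a carbonyl carbon. Within the data shown here, no measured step covers a non-aromatic ring at that carbonyl carbon; the one step at that position exchanges an aromatic ring for another aromatic ring and stays within the scatter. With nothing beyond that, the expectation in this assay is a change of no more than the scatter, in either direction. For compound 3 the expected step of a 1.3-fold higher number from compound 2 to compound 3 (0.12 log units; within the scatter) is accordingly small. Compound 3 is estimated at 85000 nM, with a range from 30000 nM to 250000 nM, and a fair chance that this assay reports only a limit for it.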

Compound 3, half-maximal inhibitory concentration: > 100000 nM
Compound 3: no number, only a limit; the forecaster's own chance of this, stated with the estimate: 45%; at least 1.1-fold (0.07 log units) between middle value and limit.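

In this assay, going by these compounds alone, cyclopropyl brings a non-aromatic ring to this carbonyl carbon for the first time, and compound 3 gives > 100000 nM, which is a limit of the assay and not a number. The change from thiophen-2-yl to cyclopropyl reads as an at least 1.5-fold higher number from compound 2 to compound 3 (0.19 log units; that floor lies within the scatter), so compound 2 stays the only one of the three with a number, and both exchanges at this position that start from it, to 4-bromophenyl and to cyclopropyl, end at a limit, with neither step shown beyond the scatter. The step between compound 1 and compound 3 cannot be read, and every size at this position rests on the same ceiling: the limit of > 100000 nM in this assay, at which 2 of the 3 values shown sit.

Open, from the compounds shown here alone, is whether any group on this carbonyl carbon brings the number in this assay down by more than the scatter, for instance a furan-2-yl ring, an amine or a longer alkyl chain. The shared core stays the same in all three compounds, so the compounds shown say nothing about changes at any other place.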